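A few compounds are considered here, and "the series" means these few. Any claim that something is new, unique, unknown or untested is made for them only; others in the source may bear on it.

Three compounds were tested in a functional assay on U-87MG ATCC cells for antiproliferative activity against U-87 MG (Homo sapiens), read by MTT assay, with a stated time of 48 h, tested at 5 uM; on this read-out higher numbers stand for a weaker effect at the one concentration tested and lower numbers for a stronger effect.

Compound 1, `COc1ccc(-c2nc(C)c(C(=O)CSc3nc(N)c(C#N)c(-c4ccc(Cl)cc4)n3)s2)cc1`, gave 51.4%.
Compound 2, `COc1ccc(-c2nc(C)c(C(=O)CSc3nc(N)c(C#N)c(-c4ccccc4)n3)s2)cc1`, gave 61.8%.
Compound 3, `Cc1nc(-c2ccccc2)sc1C(=O)CSc1nc(N)c(C#N)c(-c2ccc(Cl)cc2)n1`, gave 62.9%.

The difference between the cores of compound 2 and compound 3 is not broken down here. Between compound 2 and compound 1 the change is chloro in place of hydrogen on an aromatic carbon, and it gave a number 10.4 percentage points lower from compound 2 to compound 1 (beyond the scatter). From compound 1 to compound 3 the step was a number 11.5 percentage points higher from compound 1 to compound 3 (beyond the scatter). Compound 3 and compound 2 lie within the scatter of each other.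

Compound 4, `Cc1nc(-c2ccc(Cl)cc2)sc1C(=O)CSc1nc(N)c(C#N)c(-c2ccc(Cl)cc2)n1`, has not yet been measured in this assay. It differs from compound 3 by chloro in place of hydrogen on an aromatic carbon, the same change as from compound 2 to compound 1. Resting on the step of a number 10.4 percentage points lower from compound 2 to compound 1 (beyond the scatter), a step of similar size is expected from compound 3 to compound 4, namely a number 8.9 percentage points lower from compound 3 to compound 4 (within the scatter). Compound 4 is therefore estimated at 54%, between 44% and 65%.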

Compound 4, a percentage reported as activity, at one concentration (the size of the read-out at that concentration, not a potency): 46.1%
Compound 4: the middle estimate sits 7.9 percentage points above what was measured, and the stated range covers the measured number.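

In this assay, among these compounds, phenyl to 4-chlorophenyl gave a number 16.8 percentage points lower from compound 3 to compound 4 (beyond the scatter), so the chloro step kept its direction and its size could not be told apart on the two cores: the same change on two cores in this assay, a number 10.4 percentage points lower (beyond the scatter) from compound 2 to compound 1 and a number 16.8 percentage points lower (beyond the scatter) from compound 3 to compound 4, 6.4 percentage points apart, within the scatter of two such steps This rests on only two pairs, which carry the chloro on different phenyl groups of the molecule, so it shows no general rule and gives no reason for the step. Chloro in place of methoxy gave a number 5.3 percentage points lower from compound 1 to compound 4 (within the scatter), so the two groups are not separated here.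

Going by these compounds, whether fluoro, bromo or an amine in that place would give a different number remains open. So does how the chloro step would behave on a core with the thioether chain or the nitrile replaced.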